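The compounds below may be only part of what the source reports. "The series", "measured", "known", "first", "only" and "open" are said of these compounds alone.

Working notes on the series. Compound 1 `C#CCO/N=C1/C[C@@H](c2ccc(OC)cc2)Oc2cc(OC)c(CC=C(C)C)cc21` gives 64% in a functional assay on A549 cells (Homo sapiens) for inhibition, read by sulforhodamine B assay, with a stated time of 48 h, tested at 50 uM (a higher number here means more inhibition of growth at the concentration tested, a lower number less inhibition of growth), the second highest of the three numbers. Compound 2 `COc1ccc([C@@H]2C/C(=N/O)c3cc(CC=C(C)C)c(OC)cc3O2)cc1` gives 66%, and the step of a number 2 percentage points higher from compound 1 to compound 2 (within the scatter) sits within the scatter. Compound 3 `CCCCOc1ccc([C@@H]2CC(=O)c3cc(CC=C(C)C)c(OC)cc3O2)cc1` gives 37%, well beyond the scatter from compound 1. Compound 4 `COc1ccc([C@@H]2C/C(=N/OCc3cn(-c4cccnc4Cl)nn3)c3cc(CC=C(C)C)c(OC)cc3O2)cc1` carries the change (1-(2-chloropyridin-3-yl)-1H-1,2,3-triazol-4-yl in place of ethynyl on a saturated chain carbon bound to an oxygen on an unsaturated carbon). For the measured compounds named here, no measured step covers this change; the only step at the oxime oxygen, hydrogen in place of propargyl, changed nothing beyond the scatter, so substitution on that oxygen seems tolerated, though the group entering here is far larger. Compound 4 is therefore expected to give about 58%, between 35% and 80%, a step of a number 6 percentage points lower from compound 1 to compound 4 (within the scatter) expected to remain close to the scatter.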

Compound 4, percent growth inhibition at one concentration: 58%
Estimate against measurement, compound 4: no gap at the digits printed, within the range that was stated.
By their numbers in this assay, from the lowest: compound 3; then compounds 4, 1 and 2 (each within the scatter of the next).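

In this assay, 1-(2-chloropyridin-3-yl)-1H-1,2,3-triazol-4-yl in place of ethynyl on a saturated chain carbon bound to an oxygen on an unsaturated carbon gives a number 6 percentage points lower from compound 1 to compound 4 (within the scatter) and thus no change that can be told from the scatter. This place therefore accepts a group of 12 heavy atoms with two aromatic rings, whereas the earlier step covered only the loss of propargyl. Nothing available explains this tolerance.

Going by these compounds, whether the chlorine or the pyridine ring contributes to the number remains open. So does the outcome with a carboxylic acid or an amine on the same chain carbon.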